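This account rests on a few compounds, and the source may have more. Where it says the series, first, only, none or still open, it means among the compounds named here.

Measured compounds:
compound 1, `O=C1CC(c2ccc(Cl)cc2)Nc2c(Br)cc(Br)cc21` — 146 nM
compound 2, `O=C1CC(c2ccc(Br)cc2)Nc2c(Br)cc(Br)cc21` — 151 nM
compound 3, `O=C1CC(c2ccc([N+](=O)[O-])cc2)Nc2c(Br)cc(Br)cc21` — < 100 nM

The three measured compounds share one core and differ only in the group on the pendant phenyl ring. In a functional assay on MCF7 cells (Homo sapiens) for inhibition, read by sulforhodamine B assay, with a stated time of 48 h (a lower number here means a stronger inhibitor of growth, a higher number a weaker inhibitor of growth), compound 2 gives 151 nM and stands highest of the two numbers that are actual numbers, with compound 1 as its nearest neighbour, the two being within the scatter. For compound 3 the value of < 100 nM is a limit of the assay, not a number; the limit of < 100 nM in this assay, at which 1 of the 3 values shown sits, marks the floor at which it sits.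

Compound 4, `N#Cc1ccc(C2CC(=O)c3cc(Br)cc(Br)c3N2)cc1`, is not yet measured. It differs from compound 2 in one place: cyano in place of bromo on an aromatic carbon.

Among the measured compounds shown here, two measured steps bear on this. The step of a 1.0-fold higher number from compound 1 to compound 2 (0.01 log units; within the scatter) shows that exchanging one halogen for another leaves the number where it was. The step of an at least 1.5-fold lower number from compound 2 to compound 3 (0.17 log units; that floor lies within the scatter) shows that a nitro group in that position gives a number at the limit, though that floor still lies within the scatter. For the measured compounds named here, no measured step involves a cyano group, so the direction for compound 4 rests on these neighbours only. Compound 4 is therefore expected to give a number close to that of compound 2 or somewhat lower, with the step of a 1.3-fold lower number from compound 2 to compound 4 (0.12 log units; within the scatter) expected to stay within or just beyond the scatter. The estimate for compound 4 in this assay is 115 nM, ranging from 50 nM to 260 nM.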

Compound 4, concentration for 50% growth inhibition: < 100 nM
Compound 4 ended at the assay's limit; the forecaster's own chance of this, stated with the estimate: 35%; middle value at least 1.1-fold (0.06 log units) from the limit.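

In this assay compound 4 gives < 100 nM, which is a limit of the assay and not a number. Cyano in this place on the aromatic carbon, para to a large group, is now a second group besides nitro to end at that limit, while the chloro and bromo compounds keep measured numbers; the change reads as an at least 1.5-fold lower number from compound 2 to compound 4 (0.17 log units; that floor lies within the scatter), and the comparison with the chloro compound reads as an at least 1.4-fold lower number from compound 1 to compound 4 (0.16 log units; that floor lies within the scatter), so with both floors inside the scatter, a real gain over either halogen is possible but not shown. The step between the nitro and cyano compounds cannot be read, and the assay gives no order for this pair: the limit of < 100 nM in this assay, at which 2 of the 4 values shown sit.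

As far as these compounds go, the actual numbers of compound 3 and compound 4 remain open, and with them whether cyano and nitro differ at all in this place. Also open is what an amine, a carboxylic acid or a methoxy group would do at the same carbon of the pendant ring, where only chloro, bromo, nitro and cyano are shown.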